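A few compounds are considered here, and "the series" means these few. Any claim that something is new, unique, unknown or untested is made for them only; others in the source may bear on it.

Compound 1 `CCCCCCCCCCc1ccc(-c2noc(CCCCN)n2)cc1` and compound 2 `CCCCCCCCCCc1ccc(-c2noc([C@@H]3CCC[C@@H](N)C3)n2)cc1` share a core and differ only in the group on one aromatic carbon. In an assay on HeLa cells for inhibition of sphingosine-1-phosphate transporter SPNS2 (Mus musculus), read by LC-MS, tested at 2 uM (on this read-out higher numbers stand for more inhibition at the one concentration tested (going by the name of the read-out) and lower numbers for less inhibition), compound 1 gives 55%, and compound 2 gives 13%, the lowest of the two numbers, with the step of a number 42 percentage points lower from compound 1 to compound 2 (beyond the scatter) going beyond the scatter. Compound 3 `CCCCCCCCCCc1ccc(-c2noc(CC(CN)OC(C)=O)n2)cc1` changes that same position again: a group of 8 heavy atoms (5 carbon, 1 nitrogen, 2 oxygen; no ring) in place of a group of 7 heavy atoms (6 carbon, 1 nitrogen; one six-membered non-aromatic ring of carbon only), on an aromatic carbon. Since this step returns from the ring to a chain-like group with no ring, as in compound 1, a rise back toward compound 1 is expected, a number 22 percentage points higher from compound 2 to compound 3 (beyond the scatter), though the entering group is new and untested, so the estimate for compound 3 is 35%, between 10% and 60%.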

Compound 3, a percentage reported as inhibition, at one concentration (the size of the read-out at that concentration, not a potency): 0%
Compound 3: middle estimate off by 35 percentage points, on the high side; the measured number lies below the stated range.
By their numbers in this assay, from the lowest: compound 3; then compound 2; then compound 1.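

In this assay removing the ring does not by itself bring inhibition back: the open chain of compound 3 gives a number 13 percentage points lower from compound 2 to compound 3 (beyond the scatter) and also a number 55 percentage points lower from compound 1 to compound 3 (beyond the scatter). Among these three compounds, then, an open chain carrying an amine is not enough, and the 4-aminobutyl group of compound 1 stands highest. Nothing available explains this fall. Still open, on these data alone, is whether the oxygen-bearing branch or the shorter route to the amine matters more, and how a hydroxyl group on the chain or a longer 5-aminopentyl chain would compare.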